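The source may hold more compounds than are shown below. What is called first, only, known or untested is meant among the compounds shown, and "the series" means these compounds.

In a functional assay on UACC-257 cells (Homo sapiens) for inhibition, read by sulforhodamine B assay, with a stated time of 48 h (on this read-out lower numbers stand for stronger inhibition of growth and higher numbers for weaker inhibition of growth), compound 2 `COc1cc(-c2nn(-c3cccc(NC(=O)c4cccc(C(F)(F)F)c4)c3)cc2-c2ccncc2)ccc1Cl` gives 27900 nM, the highest of the three numbers. Compound 1 `COc1cc(-c2nn(-c3cccc(NC(=O)c4ccc(Cl)c(C(F)(F)F)c4)c3)cc2-c2ccncc2)ccc1Cl` gives 7130 nM, and compound 3 `O=C(Nc1cccc(-n2cc(-c3ccncc3)c(-c3ccc(Cl)c(O)c3)n2)c1)Nc1cc(C(F)(F)F)cc(C(F)(F)F)c1` gives 965 nM. Among the compounds with values here, the only single-point step, a 3.9-fold higher number from compound 1 to compound 2 (0.59 log units; beyond the scatter), is hydrogen in place of chloro on an aromatic carbon. Compound 4 `COc1cc(-c2nn(-c3cccc(NC(=O)Nc4cccc(C(F)(F)F)c4)c3)cc2-c2ccncc2)ccc1Cl` differs from compound 2 by (3-(trifluoromethyl)phenyl)amino in place of 3-(trifluoromethyl)phenyl on a carbonyl carbon. Within the data shown here, no measured step isolates this change; compound 3, the one urea among the three, differs from compound 2 in several places at once, and its value shows only that a urea can reach a far lower number. For compound 4 the expected step is a 2.3-fold lower number from compound 2 to compound 4 (0.37 log units; beyond the scatter), a modest one carrying wide uncertainty. The estimate for compound 4 is 12000 nM, with a range from 3000 nM to 40000 nM.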

Compound 4, concentration for 50% growth inhibition: 923 nM
For compound 4 the middle estimate is 13-fold (1.11 log units) above the measured one; measured number outside the range, below it.
By their numbers in this assay, from the lowest: compounds 4 and 3 (each within the scatter of the next); then compound 1; then compound 2.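

In this assay, putting (3-(trifluoromethyl)phenyl)amino on the carbonyl carbon gives a 30-fold lower number from compound 2 to compound 4 (1.48 log units; beyond the scatter), so this single change, with no other difference in the core, turns the amide into a urea and accounts for a large step. The urea without a chloro also improves on the chlorinated amide, with a 7.7-fold lower number from compound 1 to compound 4 (0.89 log units; beyond the scatter). Nothing measured here says why the urea differs from the amide.

Going by these compounds, it remains open whether (4-chloro-3-(trifluoromethyl)phenyl)amino would lower the number further in this urea. A carbamate oxygen or a methyl on the urea nitrogen also remains untested among the compounds shown.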